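Methoxy to Ethoxycarbonyl on an Inactive Cytotoxicity Core

The source may hold more compounds than are shown below. What is called first, only, known or untested is meant among the compounds shown, and "the series" means these compounds.

Compound 1 `O=C1COc2ccc(F)cc2N1Cc1cn(Cc2ccccc2)nn1` and compound 2 `COc1ccc2c(c1)N(Cc1cn(Cc3ccccc3)nn1)C(=O)CO2` share one core and differ only by a methoxy in place of fluoro on an aromatic carbon. In a functional assay on HT-29 cells (Homo sapiens) for cytotoxicity, read by MTT assay, with a stated time of 6 days (a higher number here means a weaker inhibitor, a lower number a stronger inhibitor), compound 1 gives > 100000 nM, which is a limit of the assay and not a number. In this assay compound 2 likewise gives > 100000 nM, again a limit rather than a number. The step that the two limits leave unreadable from compound 1 to compound 2 is therefore unreadable, since both of its values sit at the limit of > 100000 nM in this assay, at which 2 of the 2 values shown sit. Compound 2 thus stands only at a limit, with no number to place it within the series.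

Compound 3 `CCOC(=O)c1ccc2c(c1)N(Cc1cn(Cc3ccccc3)nn1)C(=O)CO2` carries the change (ethoxycarbonyl in place of methoxy on an aromatic carbon). Among the compounds with values here, no measured step bears readably on this change; the single step in hand is blank because both of its values rest at the limit of > 100000 nM in this assay, at which 2 of the 2 values shown sit.

With compound 2 itself at the limit, compound 3 is expected to remain near that limit. The step of a number no higher from compound 2 to compound 3 (the limit leaves the size open) is expected to be nothing beyond the scatter. Compound 3 is accordingly estimated at 100000 nM, with a range from 30000 nM to 300000 nM.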

Compound 3, half-maximal inhibitory concentration: 41500 nM
For compound 3 the middle estimate is 2.4-fold (0.38 log units) above the measured one; the range from low to high includes it.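

In this assay, within the data shown here, this aromatic carbon now gives a readable difference, which fluoro and methoxy did not give: compound 3, with ethoxycarbonyl, is the only one of the three compounds to carry a number rather than a limit (an at least 2.4-fold lower number from compound 2 to compound 3 (0.38 log units; beyond the scatter)). The comparison with fluoro reads the same way (an at least 2.4-fold lower number from compound 1 to compound 3 (0.38 log units; beyond the scatter)), so the value of compound 3 stands apart from the limit whichever of the two smaller groups it is set against. Going by these compounds, the true size of both steps stays open, since each starts from a value that is only a limit of the assay: the limit of > 100000 nM in this assay, at which 2 of the 3 values shown sit.

The compounds shown leave open whether the lower number belongs to ethoxycarbonyl in particular or would also appear with a carboxylic acid, an amide or a longer chain on the same aromatic carbon. On these data alone, the step between fluoro and methoxy still cannot be read, and it remains unknown how far a change elsewhere on the shared core, such as a substituent on the benzyl ring, would move the value of compound 3.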